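The source may report more compounds than this note shows. Statements on the series, on what has been measured and on what is new or still open speak of the compounds shown alone.

For the measured compounds named here, in a functional assay on the whole organism (strain CF-1) for inhibition, with Mus musculus as the target (a lower number here means that less compound is needed, a higher number that more compound is needed for the effect), compound 2 `Cc1nnc(CN(C)C)n1-c1ccc(Cl)cc1C(=O)c1ccccc1` gives 45 mg/kg, the single number in view. Compound 1 `CN(C)Cc1nnc(-c2ccco2)n1-c1ccc(Cl)cc1C(=O)c1ccccc1` gives only a limit here, > 100 mg/kg. Going by the values given here, the one measured step, an at least 2.2-fold lower number from compound 1 to compound 2 (0.34 log units; beyond the scatter), is open-ended because of the limit of > 100 mg/kg in this assay, at which 1 of the 2 values shown sits. Compound 3 `CNCc1nnc(C)n1-c1ccc(Cl)cc1C(=O)c1ccccc1` differs from compound 2 by hydrogen in place of methyl on an amine nitrogen. Among the compounds with values here, no measured step touches the amine nitrogen, so the measured change on the aromatic carbon gives no direct guide, and the expectation rests on compound 2 alone. Compound 3 is estimated at 50 mg/kg, within 20 mg/kg to 130 mg/kg. The expected step of a 1.1-fold higher number from compound 2 to compound 3 (0.05 log units; within the scatter) is thus estimated to stay within the scatter.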

Compound 3, dose for half-maximal effect: 63 mg/kg
The estimate for compound 3 lay 1.3-fold (0.10 log units) below the measured number; the range from low to high includes it.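

In this assay, the amine nitrogen, which the earlier pair left unchanged, now has a measured step of its own: a 1.4-fold higher number from compound 2 to compound 3 (0.15 log units; within the scatter). Hydrogen in place of methyl at this nitrogen therefore does not separate dimethylamino from methylamino in this assay. Nothing measured here bears on a cause for this step.

On these data alone, what stays open is whether an unsubstituted amino group, or an ethyl group on this nitrogen, would also stay within the scatter. Equally open, as far as these compounds go, is how a ring amine such as morpholine would compare with these two groups.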